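Amino in Place of Nitro: Expecting Compound 4's Cytotoxicity

The source may report more compounds than this note shows. Statements on the series, on what has been measured and on what is new or still open speak of the compounds shown alone.

In an ADME assay on MT4 cells (Homo sapiens) for cytotoxicity, read by MTT assay, with a stated time of 96 h (on this read-out higher numbers stand for lower toxicity in this test and lower numbers for higher toxicity in this test), three compounds have been measured:

compound 1, `Nc1ccc(-c2nc3cc(Cl)c(Cl)cc3[nH]2)cc1`, gives 17000 nM
compound 2, `COc1ccc(-c2nc3cc(Cl)c(Cl)cc3[nH]2)c([N+](=O)[O-])c1`, gives 2000 nM
compound 3, `O=[N+]([O-])c1ccc(-c2nc3cc(Cl)c(Cl)cc3[nH]2)cc1`, gives 17000 nM

Compound 2 gives the lowest of the three numbers, and its steps to compound 1 and to compound 3 both lie beyond the scatter. How the core of compound 2 differs from that of compound 3 is not broken down here.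

Compound 1 and compound 3 differ in one place, (amino in place of nitro on an aromatic carbon), and that change produced no change at the digits printed from compound 3 to compound 1 (within the scatter). Compound 4, `COc1ccc(-c2nc3cc(Cl)c(Cl)cc3[nH]2)c(N)c1`, has not yet been measured in this assay. It differs from compound 2 in one place, (amino in place of nitro on an aromatic carbon). For the measured compounds named here, this is the same kind of change as the one from compound 3 to compound 1, but not the same: in compound 3 the group sits para to a large group, while in compound 2 it sits ortho to a large group and meta to a methoxy group.

Going by the values given here, with only one earlier instance of this change, the expectation for compound 4 rests on it alone. The step is expected to be no change at the digits printed from compound 2 to compound 4 (within the scatter), close to the earlier step, because the change from compound 3 to compound 1 gave no change at the digits printed from compound 3 to compound 1 (within the scatter). Compound 4 is therefore estimated at 2000 nM in this assay, with a likely range from 900 nM to 4500 nM.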

Compound 4, half-maximal cytotoxic concentration: 3000 nM
The estimate for compound 4 lay 1.5-fold (0.18 log units) below the measured number, within the range that was stated.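

In this assay, amino in place of nitro on an aromatic carbon, here ortho to a large group and meta to a methoxy group, gave a 1.5-fold higher number from compound 2 to compound 4 (0.18 log units; within the scatter), so on this core too the two compounds cannot be told apart in this test. Set beside the earlier instance on the other core, the two steps do not differ: the same change on two cores in this assay, no change at the digits printed (within the scatter) from compound 3 to compound 1 and a 1.5-fold higher number (0.18 log units; within the scatter) from compound 2 to compound 4, 1.5-fold (0.18 log units) apart, within the scatter of two such steps

Within this series, then, the change carried from one core to the other without a step that stands out from the scatter, although the two cores hold the group in different surroundings, but this rests on only two pairs and does not show that it would hold on any further core, nor does it say why neither step is larger.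

The compounds shown leave open what other groups at the same place, such as a methylamino group, an acetamide or a carboxylic acid, would do to the number in this assay. They also leave open what an ethoxy or a hydroxyl group in place of the methoxy group would do on the core of compound 4.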